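A Trifluoromethyl Swap on the Amide Nitrogen

A few compounds are considered here, and "the series" means these few. Any claim that something is new, unique, unknown or untested is made for them only; others in the source may bear on it.

In a functional assay on A-431 cells (Homo sapiens) for antiproliferative activity, read by MTT assay, with a stated time of 48 h (a lower number here means a stronger inhibitor, a higher number a weaker inhibitor), compound 1 `O=C(CCCCCC(=O)Nc1ccc(O)c(C(=O)Nc2ccc(F)c(F)c2)c1)NO` gives 4010 nM and compound 2 `O=C(CCCCCC(=O)Nc1ccc(O)c(C(=O)Nc2ccc(F)c(Cl)c2)c1)NO` gives 3480 nM, so compound 2 stands level with compound 1. For the measured compounds named here, the only measured step, a 1.2-fold lower number from compound 1 to compound 2 (0.06 log units; within the scatter), puts chloro in place of fluoro on an aromatic carbon. Compound 3 `O=C(CCCCCC(=O)Nc1ccc(O)c(C(=O)Nc2cccc(C(F)(F)F)c2)c1)NO` has 3-(trifluoromethyl)phenyl in place of 3-chloro-4-fluorophenyl on an amide-type nitrogen. Going by the values given here, no measured compound carries trifluoromethyl, so that small step is a weak guide, and no clear direction is expected. The expected change is a 1.1-fold lower number from compound 2 to compound 3 (0.04 log units; within the scatter), none beyond the scatter. For compound 3 the estimate is 3200 nM, with an expected range of 1300 nM to 7500 nM.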

Compound 3, half-maximal inhibitory concentration: 2750 nM
Beside the measured number, compound 3's estimate is 1.2-fold (0.07 log units) above it, and the stated range covers the measured number.
By their numbers in this assay, from the lowest: compounds 3, 2 and 1 (each within the scatter of the next).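

Trifluoromethyl now appears on the aryl group at the amide-type nitrogen, where 3-(trifluoromethyl)phenyl gives a 1.3-fold lower number from compound 2 to compound 3 (0.10 log units; within the scatter) and, against 3,4-difluorophenyl, a 1.5-fold lower number from compound 1 to compound 3 (0.16 log units; within the scatter). In this assay, this position therefore tolerates a change from two separate halogens to a single trifluoromethyl group with no shift beyond the scatter. No available evidence bears on this result. Going by these compounds, it remains open whether an amine or a carboxylic acid on this phenyl ring would move the number beyond the scatter.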